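A few compounds are considered here, and "the series" means these few. Any claim that something is new, unique, unknown or untested is made for them only; others in the source may bear on it.

Measured in a functional assay on PC-3 cells (Homo sapiens) for inhibition, read by MTT assay, with stated times of 18 h and 4 h; on this read-out higher numbers stand for weaker inhibition and lower numbers for stronger inhibition:
- compound 1 `CCCCCCCCCCOP(=O)(O)OCCSC(=S)N1CCCCCC1`: 32900 nM
- compound 2 `CCCCCCCCOP(=O)(O)OCCSC(=S)N1CCCCC1`: > 100000 nM (a limit of the assay, not a number)
- compound 3 `CCCCCCCCCCOP(=O)(O)OCCSC(=S)N1CCCC1`: 56100 nM

Compound 3, at 56100 nM, lies within the scatter of compound 1. The only other result in the set, from compound 2, is the limit of > 100000 nM in this assay, at which 1 of the 3 values shown sits.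

The next compound is compound 4 `CCCCCCCCCCOP(=O)(O)OCCSC(=S)N1CCCCC1`, which differs from compound 3 as follows: piperidin-1-yl in place of pyrrolidin-1-yl on a thiocarbonyl carbon. In words, this is piperidin-1-yl in place of pyrrolidin-1-yl on a thiocarbonyl carbon.

Among the measured compounds shown here, the one measured step bearing on this change is a 1.7-fold higher number from compound 1 to compound 3 (0.23 log units; within the scatter), made at the same place with the chain unchanged. For the measured compounds named here, compound 2 also carries piperidin-1-yl, but its chain differs from that of compound 4, so it gives no measured step to compound 4.

No change beyond the scatter is therefore expected in this assay. The expected step is a 1.2-fold lower number from compound 3 to compound 4 (0.10 log units; within the scatter). For compound 4 the estimated value is 45000 nM, with an expected range of 22000 nM to 90000 nM.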

Compound 4, half-maximal inhibitory concentration: 62500 nM
For compound 4 the middle estimate is 1.4-fold (0.14 log units) below the measured one; low and high end bracket the measured number.
By their numbers in this assay, from the lowest: compounds 1, 3 and 4 (each within the scatter of the next). At a limit, above all of these: compound 2.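

In this assay, with the chain held constant, the thiocarbonyl carbon now carries pyrrolidin-1-yl, piperidin-1-yl or azepan-1-yl, and the new steps are a 1.1-fold higher number from compound 3 to compound 4 (0.05 log units; within the scatter) and a 1.9-fold higher number from compound 1 to compound 4 (0.28 log units; within the scatter), so compound 1, compound 3 and compound 4 do not separate beyond the scatter. Compound 2 gives a limit, not a number: the limit of > 100000 nM in this assay, at which 1 of the 4 values shown sits.

The chain change reads as an at least 1.6-fold lower number from compound 2 to compound 4 (0.20 log units; that floor lies within the scatter), so even with piperidin-1-yl held constant, the chain is not shown to matter in this assay.

On these data alone, whether morpholin-4-yl or an open-chain diethylamino group at this position would move the result beyond the scatter remains open. As far as these compounds go, the effect of the chain also remains open, and a longer chain on the piperidin-1-yl compound would test it further.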